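The compounds below may be only part of what the source reports. "The series", "measured", "known", "first", "only" and "open" are said of these compounds alone.

Within the data shown here, compound 2 `CCCCCNC(=O)CC1CCc2cc(OC)c(OC)cc21` gives 35.2% in a functional assay on the whole organism (strain Wistar) for inhibition, with Rattus norvegicus as the target, read by paw edema, with stated times of 60 min and 6 h, at a dose of 100 mg/kg by the oral route (on this read-out higher numbers stand for more inhibition at the one dose given (going by the name of the read-out) and lower numbers for less inhibition), the higher of the two numbers measured so far, although the step of a number 7.4 percentage points higher from compound 1 to compound 2 (within the scatter) lies within the scatter, so compound 1 `COc1cc2c(cc1OC)C(CC(N)=O)CC2` with its 27.8% cannot be set apart from it. Compound 3 `COc1cc2c(cc1OC)C(CC(=O)NCCO)CC2` differs from compound 2 by hydroxy in place of propyl on a saturated chain carbon, two bonds along the chain from an amide-type nitrogen. Among the measured compounds shown here, the only measured step that bears on this change is the one at the same amide nitrogen, where pentyl replaced hydrogen and a number 7.4 percentage points higher from compound 1 to compound 2 (within the scatter) resulted, a shift that did not exceed the scatter. Nothing measured shows what a hydroxy at this place does. Since the amide substituent has so far moved inhibition only within the scatter, the step of a number 3.2 percentage points lower from compound 2 to compound 3 (within the scatter) is expected to remain within the scatter as well. Compound 3 is therefore estimated at 32%, with a range from 18% to 46%.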

Compound 3, a percentage reported as inhibition, in the whole organism at one dose (the size of the read-out at that dose, not a potency): 13%
Estimate against measurement, compound 3: 19 percentage points above; measured number below the stated range.
By their numbers in this assay, from the lowest: compound 3; then compounds 1 and 2 (each within the scatter of the next).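

The amide nitrogen of the shared core is not indifferent in this assay: hydroxy in place of propyl on a saturated chain carbon, two bonds along the chain from an amide-type nitrogen, gives a number 22.2 percentage points lower from compound 2 to compound 3 (beyond the scatter). The earlier compounds shown here showed only a pentyl substituent, with a number 7.4 percentage points higher from compound 1 to compound 2 (within the scatter), whereas 2-hydroxyethyl in place of hydrogen on that nitrogen gives a number 14.8 percentage points lower from compound 1 to compound 3 (beyond the scatter), so the first substituent on this nitrogen to stand apart from the unsubstituted amide is the one carrying hydroxy. Nothing given here accounts for this fall. The compounds shown do not separate the entry of hydroxy from the loss of propyl, and a hydroxy at the end of a longer chain could tell these apart. They also leave open whether an amine or a carboxylic acid in the place of that hydroxy would give a similar number.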